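A Mirror Image in Buffer

The compounds below may be only part of what the source reports. "The series", "measured", "known", "first", "only" and "open" are said of these compounds alone.

In a physicochemical assay for metabolic stability, read by HPLC, in phosphate buffer, with a stated time of 12 h, at pH 6.8 (a lower number here means that the compound disappears faster, a higher number that the compound lasts longer), compound 2 `O=C(N[C@H](CO)C(=O)O)[C@@H]1C[C@H](O)CN1` gives > 12 h as its reading, and this is a limit of the assay and not a number. Compound 1 `O=C(O)[C@@H](CO)NC(=O)[C@H]1C[C@H](O)CN1` gives > 12 h as its reading, which is also a limit. Going by the values given here, the only measured step is a step that the two limits leave unreadable from compound 1 to compound 2 and so offers no size to carry forward. The change to compound 3 `O=C(O)[C@H](CO)NC(=O)[C@H]1C[C@@H](O)CN1` is this: the two compounds have the same atoms and bonds and differ only in configuration as drawn: 3 of 3 stereo elements differ (all stereocentres are inverted: mirror images); a stereocentre at a saturated chain carbon is drawn R in compound 2 and S in compound 3; a stereocentre at a saturated ring carbon is drawn S in compound 2 and R in compound 3; a stereocentre at a saturated ring carbon is drawn S in compound 2 and R in compound 3 and no group leaves or enters. With compound 2 at the limit of > 12 h and no atom or bond altered, no step beyond the usual scatter is expected in this assay in either direction. The estimated step is a step that the limit leaves unreadable from compound 2 to compound 3 and so amounts to no real change. Compound 3 is expected at 20 h within a range of 12 h to 40 h and may well read out only as a limit.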

Compound 3, half-life: > 12 h
Compound 3: only a limit was reported; the forecaster's own chance of this, stated with the estimate: 90%; the middle value is on the limit's open side.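

No new step can be read among compound 1, compound 2 and compound 3, because all three share one reading, which is a limit and not a number: the limit of > 12 h in this assay, at which 3 of the 3 values shown sit.

The compounds shown leave open how long each one actually lasts in this assay, and whether configuration changes that at all.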